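A Pyridin-2-yl Group Becomes Pyridin-3-yl

The source may report more compounds than this note shows. Statements on the series, on what has been measured and on what is new or still open speak of the compounds shown alone.

In a functional assay on DU-145 cells (Homo sapiens) for cytotoxicity, read by ELISA, with a stated time of 2 days (on this read-out higher numbers stand for weaker inhibition and lower numbers for stronger inhibition), compound 1 (`Oc1cccc(-c2cc(-c3ccccc3)nc(-c3ccccc3)c2)c1`) reads 17900 nM and compound 2 (`Oc1cccc(-c2cc(-c3ccccc3)nc(-c3ccsc3)c2)c1`) reads 11700 nM while compound 3 (`Oc1cccc(-c2cc(-c3ccccc3)nc(-c3ccccn3)c2)c1`) reads 15500 nM and so sits within the scatter of both. Compound 4 (`Oc1cccc(-c2cc(-c3ccccc3)nc(-c3cccnc3)c2)c1`) has pyridin-3-yl in place of pyridin-2-yl on an aromatic carbon so the same atoms are joined differently. Three measured swaps on that carbon bear on this: a 1.5-fold lower number from compound 1 to compound 2 (0.18 log units; within the scatter) for thiophen-3-yl and a 1.2-fold lower number from compound 1 to compound 3 (0.06 log units; within the scatter) for pyridin-2-yl and a 1.3-fold higher number from compound 2 to compound 3 (0.12 log units; within the scatter) between those two. None of them moved the number beyond the scatter, so no such move is expected here. The expected change is a 1.1-fold lower number from compound 3 to compound 4 (0.03 log units; within the scatter) and lies within the scatter. For compound 4 the estimated value is 14500 nM with an expected range from 7500 nM to 27000 nM in this read-out.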

Compound 4, half-maximal inhibitory concentration: 18900 nM
Estimate against measurement, compound 4: 1.3-fold (0.12 log units) below; low and high end bracket the measured number.
By their numbers in this assay, from the lowest: compounds 2, 3, 1 and 4 (each within the scatter of the next).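

Changing only where the ring nitrogen sits, with pyridin-3-yl in place of pyridin-2-yl, gives a 1.2-fold higher number from compound 3 to compound 4 (0.09 log units; within the scatter) in this assay and so leaves the number within the scatter. The comparisons with the other groups agree, with a 1.6-fold higher number from compound 2 to compound 4 (0.21 log units; within the scatter) and a 1.1-fold higher number from compound 1 to compound 4 (0.02 log units; within the scatter) as the remaining steps, so all four aromatic groups on this carbon read alike here. No measurement shown gives a reason for this.

On these data alone, whether an amine, a carboxylic acid or a longer chain on this carbon would move the number beyond the scatter stays open.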